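Urea aryl swap on a triazolylpyridine ether scaffold

The source may hold more compounds than are shown below. What is called first, only, known or untested is meant among the compounds shown, and "the series" means these compounds.

Measured compounds:
compound 1 `CCN(CC)CCn1cnnc1-c1cc(Oc2ccc(NC(=O)Nc3ccc(F)c(F)c3)cc2F)ccn1`: > 50000 nM
compound 2 `CN(C)CCCn1cnnc1-c1cc(Oc2ccc(NC(=O)Nc3cccc(C(F)(F)F)c3)cc2F)ccn1`: 11600 nM

In an ADME assay on WI-38 cells (Homo sapiens) for cytotoxicity, read by MTT assay, with a stated time of 72 h (on this read-out higher numbers stand for weaker inhibition and lower numbers for stronger inhibition), compound 2 gives 11600 nM. Among the compounds with values here, this is the only number obtained; the other result is a limit of the assay. For compound 1 the result of > 50000 nM is such a limit (the limit of > 50000 nM in this assay, at which 1 of the 2 values shown sits). Within the data shown here, compound 1 and compound 2 differ in two places, so no single step can be read between them; their values show only that compound 1 sits at the limit while compound 2 returns a number.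

Compound 3 `CN(C)CCCn1cnnc1-c1cc(Oc2ccc(NC(=O)Nc3ccc(F)c(F)c3)cc2F)ccn1` has not yet been measured in this assay. It differs from compound 2 in one place: 3,4-difluorophenyl in place of 3-(trifluoromethyl)phenyl on an amide-type nitrogen. Compound 3 thereby carries the same 3,4-difluorophenyl urea as compound 1, whose result in this assay is the limit > 50000 nM. On that basis compound 3 is expected to show weaker inhibition than compound 2, a step from compound 2 to compound 3 estimated as a 2.6-fold higher number from compound 2 to compound 3 (0.41 log units; beyond the scatter), though a step within the scatter cannot be ruled out. The estimate for compound 3 in this assay is 30000 nM, within 9000 nM to 100000 nM, with a fair chance that only a limit is reported.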

Compound 3, half-maximal inhibitory concentration: 15300 nM
Beside the measured number, compound 3's estimate is 2.0-fold (0.29 log units) above it, and the stated range covers the measured number.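

In this assay, 3,4-difluorophenyl in place of 3-(trifluoromethyl)phenyl on an amide-type nitrogen gives a 1.3-fold higher number from compound 2 to compound 3 (0.12 log units; within the scatter), so the two aryl groups cannot be told apart on this scaffold with this chain. Within the data shown here, the other change, (dimethylamino)methyl in place of diethylamino on a saturated chain carbon, two bonds along the chain from an aromatic nitrogen, gives an at least 3.2-fold lower number from compound 1 to compound 3 (0.51 log units; beyond the scatter), the first readable step beyond the scatter, and with the 3,4-difluorophenyl urea held fixed, this chain change alone separates a limit from a number. The result for compound 1 is a limit of the assay and not a number, so this step gives only a minimum size: the limit of > 50000 nM in this assay, at which 1 of the 3 values shown sits.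

The compounds shown leave open whether the same chain change would carry over to the 3-(trifluoromethyl)phenyl urea, and how far the true value of compound 1 lies past its limit. They also leave open how a morpholine at the end of the chain, or an unsubstituted phenyl on the urea, would read in this assay.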